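A few compounds are considered here, and "the series" means these few. Any claim that something is new, unique, unknown or untested is made for them only; others in the source may bear on it.

Compound 1 `Cc1ccc(-c2ccnc(Nc3ccc4c(c3)c(/C=C3/C(=O)Nc5ccccc53)cn4C)n2)cc1` gives > 100000 nM in a functional assay on PA-1 cells (Homo sapiens) for cytotoxicity, read by MTT assay, with a stated time of 48 h; a higher number here means a weaker inhibitor, a lower number a stronger inhibitor; this value is a limit of the assay, not a number.
Compound 2 `COc1ccc(-c2ccnc(Nc3ccc4c(c3)c(/C=C3/C(=O)Nc5ccccc53)cn4C)n2)cc1` gives > 100000 nM in this assay; this too is a limit of the assay, not a number.
Compound 3 `Cn1cc(/C=C2/C(=O)Nc3ccccc32)c2cc(Nc3nccc(-c4ccc(F)cc4)n3)ccc21` gives 31800 nM in this assay.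

Compound 2 therefore stands at the limit of > 100000 nM in this assay, at which 2 of the 3 values shown sit, so its own potency is known only as weaker than that limit, not as a figure. Compound 4 `Cn1cc(/C=C2/C(=O)Nc3ccccc32)c2cc(Nc3nccc(-c4ccc(C(F)(F)F)cc4)n3)ccc21`, not yet measured, differs from compound 2 by trifluoromethyl in place of methoxy on an aromatic carbon.

Within the data shown here, two measured steps touch this position. The change from methoxy to methyl, a step that the two limits leave unreadable from compound 1 to compound 2, cannot be read, since both compounds sit at the limit. The change to fluoro, an at least 3.1-fold lower number from compound 2 to compound 3 (0.49 log units; beyond the scatter), shows that replacing methoxy at this position with a fluorine-bearing group can bring the number down at least modestly. Trifluoromethyl is a different group from fluoro, so the measured steps give only a rough guide; a drop of similar or smaller size is expected, with a real chance that compound 4 also comes back only as a limit.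

Compound 4 is therefore expected to give 60000 nM in this assay, within 20000 nM to 200000 nM.
This estimate means an expected step of an at least 1.6-fold lower number from compound 2 to compound 4 (0.22 log units; that floor lies within the scatter).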

Compound 4, half-maximal inhibitory concentration: 63900 nM
The estimate for compound 4 lay 1.1-fold (0.03 log units) below the measured number; the range from low to high includes it.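

Compound 4 gives this position a second measured number in this assay, so two groups can now be compared directly rather than against a limit: the step is a 2.0-fold higher number from compound 3 to compound 4 (0.30 log units; within the scatter), and trifluoromethyl and fluoro cannot be told apart here. The comparisons with the other groups are weaker than those made with compound 3, whose steps cleared the scatter: the change from 4-methoxyphenyl to 4-(trifluoromethyl)phenyl gives an at least 1.5-fold lower number from compound 2 to compound 4 (0.19 log units; that floor lies within the scatter), and the change from methyl gives an at least 1.5-fold lower number from compound 1 to compound 4 (0.19 log units; that floor lies within the scatter), so compound 4 alone does not establish that trifluoromethyl improves on methoxy or methyl. The full size of these two steps stays unknown, as compound 1 and compound 2 each rest on a limit: the limit of > 100000 nM in this assay, at which 2 of the 4 values shown sit.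

The compounds shown leave open what an amine, a carboxylic acid or a longer chain would give at this position. Among these compounds, they also leave open whether any group here can bring the number well below those of compound 3 and compound 4, since only two fluorine-bearing groups have given readable values so far.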